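Nitro for trifluoromethyl on compound 1

This account rests on a few compounds, and the source may have more. Where it says the series, first, only, none or still open, it means among the compounds named here.

Among the measured compounds shown here, in a functional assay on HCT-116 cells (Homo sapiens) for antiproliferative activity, read by MTT assay, with a stated time of 72 h (a higher number here means a weaker inhibitor, a lower number a stronger inhibitor), compound 1 (`COc1ccc(/C=C2/CN(C)/C(=N/c3ccc(C(F)(F)F)cc3)S2)cc1`) gives 34300 nM and holds the higher of the two numbers known so far. Compound 2 (`FC(F)(F)c1cc(/N=C2/NC/C(=C/c3ccccc3)S2)cc(C(F)(F)F)c1`) gives 16100 nM and lies lower by a gap beyond the usual scatter. Compound 3 (`COc1ccc(/C=C2/CN(C)/C(=N/c3ccc([N+](=O)[O-])cc3)S2)cc1`) differs from compound 1 by nitro in place of trifluoromethyl on an aromatic carbon. For the measured compounds named here, no measured pair shows this change, and no step beyond the scatter is expected in this assay here. The expected step is a 1.3-fold lower number from compound 1 to compound 3 (0.10 log units; within the scatter) and points slightly toward a lower number. Compound 3 is expected at 27000 nM (11000 nM to 60000 nM) in this estimate.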

Compound 3, half-maximal inhibitory concentration: 10200 nM
Estimate against measurement, compound 3: 2.6-fold (0.42 log units) above; measured number outside the range, below it.
By their numbers in this assay, from the lowest: compounds 3 and 2 (each within the scatter of the next); then compound 1.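

In this assay, nitro in place of trifluoromethyl on this aromatic carbon, para to a large group, gives a 3.4-fold lower number from compound 1 to compound 3 (0.53 log units; beyond the scatter) and so provides the first measured sign that the group at this position bears on the number. The earlier compounds shown here offered no such comparison, as they differ in more than one place. No available evidence explains the step.

This single pair leaves open how other groups at this position, such as an amine, a nitrile or a carboxylic acid, would read. It also leaves open whether the same change would give a similar step on another core.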